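Cytotoxicity in the amide series: weighing a phenyl-oxazole replacement

This account rests on a few compounds, and the source may have more. Where it says the series, first, only, none or still open, it means among the compounds named here.

Compound 1 `O=C(Nc1c(O)cccc1-c1nc2c(C(=O)O)cccc2o1)c1ccccn1` is the reference of the set. In an ADME assay on L6 cells (Rattus norvegicus) for cytotoxicity (on this read-out higher numbers stand for weaker inhibition and lower numbers for stronger inhibition), compound 1 gives 30600 nM, the lowest of the two plain numbers shown; compound 2 `O=C(Nc1c(O)cccc1-c1nc2c(C(=O)O)cccc2o1)c1ccccc1O` comes nearest with 85100 nM. Compound 3 `O=C(Nc1c(O)cccc1-c1nc2c(C(=O)O)cccc2o1)c1ccccc1` is reported only as a limit of the assay, > 240000 nM, as noted under (the limit of > 240000 nM in this assay, at which 1 of the 3 values shown sits).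

Two measured steps leave compound 1 and both touch the same place, the carbonyl carbon. Replacing the pyridin-2-yl with 2-hydroxyphenyl gives a 2.8-fold higher number from compound 1 to compound 2 (0.44 log units; beyond the scatter); replacing it with phenyl gives an at least 7.8-fold higher number from compound 1 to compound 3 (0.89 log units; beyond the scatter). The move from compound 2 to compound 3 adds an at least 2.8-fold higher number from compound 2 to compound 3 (0.45 log units; beyond the scatter).

Compound 4 `O=C(Nc1c(O)cccc1-c1nc2c(C(=O)O)cccc2o1)c1cc(-c2ccccc2)on1` differs from compound 1 as follows: 5-phenyl-1,2-oxazol-3-yl in place of pyridin-2-yl on a carbonyl carbon. Both measured exchanges at this position moved the number upward, so a step in the same direction, of modest size, is expected for compound 4 in this assay, with a real chance that only a limit is returned.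

Compound 4 is therefore estimated at 70000 nM, within 22000 nM to 240000 nM, which corresponds to an expected 2.3-fold higher number from compound 1 to compound 4 (0.36 log units; beyond the scatter).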

Compound 4, half-maximal inhibitory concentration: 141000 nM
For compound 4 the middle estimate is 2.0-fold (0.30 log units) below the measured one; the measured number falls inside the stated range.
By their numbers in this assay, from the lowest: compound 1; then compounds 2 and 4 (each within the scatter of the next). At a limit, above all of these: compound 3.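

Working notes: in this assay, 5-phenyl-1,2-oxazol-3-yl is a third replacement of pyridin-2-yl on the carbonyl carbon that raises the number, with a 4.6-fold higher number from compound 1 to compound 4 (0.66 log units; beyond the scatter), so all three exchanges shown at this position go the same way. The 5-phenyl-1,2-oxazol-3-yl and 2-hydroxyphenyl groups are not separated on this read-out, with a 1.7-fold higher number from compound 2 to compound 4 (0.22 log units; within the scatter). Against phenyl, an at least 1.7-fold lower number from compound 3 to compound 4 (0.23 log units; that floor lies within the scatter) gives no order of the two groups, since compound 3 stands at a limit: the limit of > 240000 nM in this assay, at which 1 of the 4 values shown sits.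

As far as these compounds go, how a pyridin-3-yl or an aminomethyl group on this carbonyl carbon would read remains open. Also open, from the compounds shown here alone, is whether the five-membered aromatic ring or its phenyl substituent accounts for the step away from compound 1.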